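Hydroxyacyl side chain variation and microsomal clearance

This account rests on a few compounds, and the source may have more. Where it says the series, first, only, none or still open, it means among the compounds named here.

Compound 1 `O=C(NCc1cc(Cl)ccc1-n1cnnn1)[C@@H]1[C@H]2C[C@H]2CN1C(=O)[C@H](O)CC1CC1` — in an ADME assay on liver for metabolic stability, with Liver microsome (Homo sapiens) as the target, read by LC-MS, using microsomes (a higher number here means faster removal of the compound, a lower number slower removal), compound 1 gives only the assay limit < 14 mL.min-1.g-1.
Compound 2 `CCCC[C@@H](O)C(=O)N1N=CC[C@H]1C(=O)NCc1cc(Cl)ccc1-n1cnnn1` — in this assay compound 2 gives only the assay limit < 12 mL.min-1.g-1.

Compound 2 stands at the limit of this assay, as compound 1 does; both values are limits, so no number separates them. Among the measured compounds shown here, no step between measured compounds is at hand, so no measured size of change guides the next comparison. Compound 3 `COC(C)(C)[C@@H](O)C(=O)N1N=CC[C@H]1C(=O)NCc1cc(Cl)ccc1-n1cnnn1` differs from compound 2 by 1-methoxy-1-methylethyl in place of butyl on a saturated chain carbon bound to a carbonyl carbon and an oxygen on a saturated carbon. The expected step that the limit leaves unreadable from compound 2 to compound 3 is none beyond the scatter, the expectation resting on compound 2 sitting at the limit of < 12 mL.min-1.g-1 in this assay, at which 1 of the 2 values shown sits. Compound 3 is therefore expected to give about 10 mL.min-1.g-1, within 4 mL.min-1.g-1 to 25 mL.min-1.g-1, most likely again reported as a limit.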

Compound 3, intrinsic clearance in microsomes: < 12 mL.min-1.g-1
Compound 3 ended at the assay's limit; the forecaster's own chance of this, stated with the estimate: 65%; the middle value does not contradict the limit.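

Compound 2 and compound 3 both give only a limit in this assay, so no step can be read between them. As far as these compounds go, whether 1-methoxy-1-methylethyl in place of butyl shifts clearance at all stays open.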